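This account rests on a few compounds, and the source may have more. Where it says the series, first, only, none or still open, it means among the compounds named here.

Measured in a physicochemical assay for solubility, at pH 7.4; on this read-out lower numbers stand for lower solubility and higher numbers for higher solubility:
- compound 1 `C[C@H](N)C(=O)N[C@@H]1CN(c2nc3c(cc2F)c(=O)c(C(=O)O)cn3C2CC2)[C@H]1C`: > 500 ug/mL (a limit)
- compound 2 `C[C@@H]1[C@@H](NC(=O)[C@@H](C)N)CN1c1nc2c(cc1F)c(=O)c(C(=O)O)cn2C1CC1`: > 500 ug/mL (a limit)

Compound 1 therefore stands only at a limit and has no exact value. Compound 3 `C[C@@H](N)C(=O)N[C@@H]1CN(c2nc3c(cc2F)c(=O)c(C(=O)O)cn3C2CC2)[C@H]1C` differs from it as follows: the two compounds have the same atoms and bonds and differ only in configuration as drawn: 1 of 3 stereo elements differ; a stereocentre at a saturated chain carbon is drawn S in compound 1 and R in compound 3. Among the compounds with values here, only the saturated chain carbon is redrawn, from S to R. The one measured step, a step that the two limits leave unreadable from compound 1 to compound 2, inverts all stereocentres and gives no size, and both compounds sit at the limit of > 500 ug/mL in this assay, at which 2 of the 2 values shown sit. On that basis, no step beyond the scatter is expected in this assay, and no direction can be foreseen. The expected step is a step that the limit leaves unreadable from compound 1 to compound 3. Compound 3 is estimated at 600 ug/mL, with an expected range of 300 ug/mL to 1500 ug/mL.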

Compound 3, solubility: 386 ug/mL
The estimate for compound 3 lay 1.6-fold (0.19 log units) above the measured number; the range from low to high includes it.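

Within the data shown here, with compound 3, this assay gives the first exact number in this set, and the saturated chain carbon is redrawn on its own. Redrawing that carbon from S to R gives an at least 1.2-fold lower number from compound 1 to compound 3 (0.11 log units; that floor lies within the scatter). Redrawing the two saturated ring carbons gives an at least 1.2-fold lower number from compound 2 to compound 3 (0.11 log units; that floor lies within the scatter).

From the compounds shown here alone, compound 1 and compound 2 each stand at a limit, and the full size of both steps stays open. Also open, going by these compounds, is how a longer chain at the saturated chain carbon would read in this assay.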